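The source may hold more compounds than are shown below. What is called first, only, known or untested is meant among the compounds shown, and "the series" means these compounds.

Compounds measured so far:
- compound 1, `OC[C@H]1O[C@@H](n2cnc3c(NCc4ccccc4F)ncnc32)[C@H](O)[C@@H]1O`: 4600 nM
- compound 2, `COc1ccc(CNc2ncnc3c2ncn3[C@@H]2O[C@H](CO)[C@@H](O)[C@H]2O)c(OC)c1`: > 166000 nM

Series notes. For the measured compounds named here, in a functional assay on CCRF-CEM cells (Homo sapiens) for antiproliferative activity, with a stated time of 72 h (on this read-out lower numbers stand for stronger inhibition and higher numbers for weaker inhibition), compound 1 gives 4600 nM, the only number obtained so far in this assay. For compound 2 the assay returns only a limit, > 166000 nM, and no number. Going by the values given here, the one step between measured compounds is an at least 36-fold higher number from compound 1 to compound 2 (1.55 log units; beyond the scatter), with the size read against (the limit of > 166000 nM in this assay, at which 1 of the 2 values shown sits).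

The next compound, compound 3, is `OC[C@H]1O[C@@H](n2cnc3c(NCc4ccc(F)cc4Cl)ncnc32)[C@H](O)[C@@H]1O`. It differs from compound 1 as follows: 2-chloro-4-fluorophenyl in place of 2-fluorophenyl on a saturated chain carbon bound to a nitrogen on an aromatic ring. The measured step from compound 1 to compound 2 bears on this change only loosely: it alters the same position, but the group entering there was 2,4-dimethoxyphenyl, whereas here 2-chloro-4-fluorophenyl enters and the 2-fluorophenyl pattern of compound 1 is partly retained. Among the compounds with values here, no measured pair shows this particular change. The expectation for compound 3 is therefore a step from compound 1 within the usual scatter, with a slightly wider allowance for the weaker side, given the size of an at least 36-fold higher number from compound 1 to compound 2 (1.55 log units; beyond the scatter).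

Estimate for compound 3 in this assay: 5000 nM, range 1500 nM to 20000 nM, a step of a 1.1-fold higher number from compound 1 to compound 3 (0.04 log units; within the scatter) expected from compound 1.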

Compound 3, half-maximal inhibitory concentration: 20900 nM
The estimate for compound 3 lay 4.2-fold (0.62 log units) below the measured number; measured number outside the range, above it.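

In this assay, the place on a saturated chain carbon bound to a nitrogen on an aromatic ring responds not only to the large exchange for 2,4-dimethoxyphenyl but also to a change that keeps a halogen-bearing phenyl: 2-chloro-4-fluorophenyl in place of 2-fluorophenyl gives a 4.5-fold higher number from compound 1 to compound 3 (0.66 log units; beyond the scatter). Among these three compounds the groups fall into three separate levels, since 2-chloro-4-fluorophenyl still gives a measured number and replacing 2,4-dimethoxyphenyl with it gives an at least 7.9-fold lower number from compound 2 to compound 3 (0.89 log units; beyond the scatter), which places compound 3 between compound 1 and compound 2. The size of that second step is only a lower bound, read against a limit and not a number: the limit of > 166000 nM in this assay, at which 1 of the 3 values shown sits.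

The chlorine and the added fluorine enter together in compound 3, so the share of each in the step cannot be separated from these compounds alone. Also open, as far as these compounds go, is how this place responds to an unsubstituted phenyl, to an amine or a carboxylic acid on the phenyl ring, or to a longer chain in place of the single chain carbon, with the shared core held constant.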